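Three Cytotoxicity Readings and a Fourth Expected

The source may report more compounds than this note shows. Statements on the series, on what has been measured and on what is new or still open speak of the compounds shown alone.

Measured compounds:
Compound 1 `Cc1ccc(Cn2nnc(-c3cc([N+](=O)[O-])cc([N+](=O)[O-])c3)n2)cc1` gives 200000 nM in an ADME assay on CHO-K1 cells (Cricetulus griseus) for cytotoxicity, read by MTT assay, with a stated time of 24 h; a higher number here means a weaker inhibitor, a lower number a stronger inhibitor.
Compound 2 `O=[N+]([O-])c1cc(-c2nnn(Cc3ccc(Cl)cc3)n2)cc([N+](=O)[O-])c1` gives 170000 nM in this assay.
Compound 3 `O=[N+]([O-])c1cc(-c2nnn(Cc3cccc(Br)c3)n2)cc([N+](=O)[O-])c1` gives 29000 nM in this assay.

Compound 3 has the lowest number of the three in this assay. Its nearest neighbour is compound 2, with a 5.9-fold lower number from compound 2 to compound 3 (0.77 log units; beyond the scatter), and the furthest is compound 1, with a 6.9-fold lower number from compound 1 to compound 3 (0.84 log units; beyond the scatter). Between compounds 1 and 2 themselves the difference is a 1.2-fold lower number from compound 1 to compound 2 (0.07 log units; within the scatter).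

Compound 4 `O=[N+]([O-])c1cc(-c2nnn(Cc3ccc(F)cc3)n2)cc([N+](=O)[O-])c1` has not yet been measured. It differs from compound 3 in one place: 4-fluorophenyl in place of 3-bromophenyl on a saturated chain carbon bound to an aromatic nitrogen. The change returns the substituent pattern to that of compounds 1 and 2, which carry 4-methylphenyl and 4-chlorophenyl on the same carbon, and those two compounds sit within the scatter of each other and well above compound 3. The step that bears most directly is a 5.9-fold lower number from compound 2 to compound 3 (0.77 log units; beyond the scatter), a modest move that compound 4 is expected to undo, at least in part. The estimate for compound 4 is therefore a number back near compounds 1 and 2, a step of a 5.2-fold higher number from compound 3 to compound 4 (0.71 log units; beyond the scatter), giving an expected 150000 nM with a range from 50000 nM to 300000 nM.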

Compound 4, half-maximal inhibitory concentration: 35000 nM
Estimate against measurement, compound 4: 4.3-fold (0.63 log units) above; the whole stated range lies above it.
By their numbers in this assay, from the lowest: compounds 3 and 4 (each within the scatter of the next); then compounds 2 and 1 (each within the scatter of the next).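

In this assay, compound 4 shows that the low reading of compound 3 is not tied to 3-bromophenyl: with 4-fluorophenyl on the saturated chain carbon bound to an aromatic nitrogen, the exchange gives a 1.2-fold higher number from compound 3 to compound 4 (0.08 log units; within the scatter) and leaves the two readings within the scatter of each other. The earlier compounds shown here could be read as placing every ring substituted like those of compound 1 and compound 2 at the high end, but the substituent itself proves to count at this place, with a 4.9-fold lower number from compound 2 to compound 4 (0.69 log units; beyond the scatter) for fluoro in place of chloro and a 5.7-fold lower number from compound 1 to compound 4 (0.76 log units; beyond the scatter) for fluoro in place of methyl, both modest steps beyond the scatter. No measurement at hand explains why fluoro parts from chloro and methyl here.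

With bromo seen only in 3-bromophenyl and fluoro only in 4-fluorophenyl, the compounds shown do not separate the identity of the halogen from its place on the ring. Also open, going by these compounds, is where an unsubstituted phenyl, a methoxy-bearing phenyl or a longer chain on that aromatic nitrogen would fall.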